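Swapping methyl for chloro on the aryl ring of compound 2

The compounds below may be only part of what the source reports. "The series", "measured", "known", "first", "only" and "open" are said of these compounds alone.

Measured compounds:
Compound 1 `Fc1ccc(C2=NN(c3nc(-c4ccc(Br)cc4)cs3)C(c3cccs3)C2)cc1` gives 8280 nM
Compound 2 `Cc1ccc(C2=NN(c3nc(-c4ccc(Br)cc4)cs3)C(c3cccs3)C2)cc1` gives 2010 nM
Compound 3 `Cc1ccc(C2=NN(c3nc(-c4ccccc4)cs3)C(c3cccs3)C2)cc1` gives 18600 nM

In a functional assay on MCF7 cells (Homo sapiens) for antiproliferative activity, read by MTT assay, with a stated time of 48 h (on this read-out higher numbers stand for weaker inhibition and lower numbers for stronger inhibition), compound 2 stands at the lowest number of the three, with compound 1 as its nearest neighbour, a 4.1-fold lower number from compound 1 to compound 2 (0.61 log units; beyond the scatter), and compound 3 furthest away, a 9.3-fold higher number from compound 2 to compound 3 (0.97 log units; beyond the scatter).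

Compound 4 `Clc1ccc(C2=NN(c3nc(-c4ccc(Br)cc4)cs3)C(c3cccs3)C2)cc1` differs from compound 2 in one place: chloro in place of methyl on an aromatic carbon. Going by the values given here, of the measured steps only the one from compound 1 to compound 2 touches the same place, and there a halogen was replaced by methyl with a modest gain, a 4.1-fold lower number from compound 1 to compound 2 (0.61 log units; beyond the scatter). The step from compound 2 to compound 3 changes a different ring and says nothing about this spot. Putting a halogen back at this place, now a chloro rather than a fluoro, is therefore expected to move the number in this assay somewhat upward, though less than the whole way back to compound 1. Compound 4 is estimated at 3500 nM, within a range of 1200 nM to 10000 nM, which would mean a step of a 1.7-fold higher number from compound 2 to compound 4 (0.24 log units; within the scatter).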

Compound 4, half-maximal inhibitory concentration: 14700 nM
Compound 4: the middle estimate sits 4.2-fold (0.62 log units) below what was measured; measured number above the stated range.
By their numbers in this assay, from the lowest: compound 2; then compounds 1, 4 and 3 (each within the scatter of the next, the first and the last beyond it).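

In this assay, replacing methyl with chloro on the carbon para to a large group gives a 7.3-fold higher number from compound 2 to compound 4 (0.86 log units; beyond the scatter), so the loss seen earlier with fluoro is not confined to that one halogen. Fluoro and chloro cannot be told apart here, with a 1.8-fold higher number from compound 1 to compound 4 (0.25 log units; within the scatter), which leaves methyl as the better of the three groups at this place, as long as the bromo on the other aryl ring stays. Nothing measured here bears on why methyl differs from these two halogens.

The compounds shown leave open whether a methoxy or an ethyl group at this place would match methyl, and how a plain hydrogen there would compare. They also leave open whether chloro would still give a higher number than methyl on the core of compound 3, which lacks the bromo.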